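A few compounds are considered here, and "the series" means these few. Any claim that something is new, unique, unknown or untested is made for them only; others in the source may bear on it.

Compound 1 (`COc1ccc(SCc2ccc(C(=O)Nc3ccccc3N)cc2)cc1`) gives 10.2% in a functional assay on A-375 cells (Homo sapiens) for inhibition, read by CCK-8 assay, with a stated time of 72 h, tested at 2 uM (on this read-out higher numbers stand for more inhibition of growth at the one concentration tested and lower numbers for less inhibition of growth), at the single concentration tested. Compound 2 (`COc1ccc(SCc2ccc(C(=O)Nc3ccccc3N)cc2)cc1OC`) gives 18.1% on the same read-out, so the two numbers lie within the scatter of each other and neither can be set apart from the other. Compound 3 (`Nc1ccccc1NC(=O)c1ccc(CSCCc2ccccc2)cc1`) keeps the core of compound 1 but carries phenethyl in place of 4-methoxyphenyl on a sulfur and has not yet been measured. Going by the values given here, the one measured step on the shared core is a number 7.9 percentage points higher from compound 1 to compound 2 (within the scatter) for methoxy in place of hydrogen on an aromatic carbon. Among the compounds with values here, that step alters the same aromatic group that leaves in compound 3, but no measured compound carries phenethyl, so it is only a loose guide. The expectation in this assay is therefore for no step beyond the scatter and for no firm direction. The estimated step is a number 4.8 percentage points higher from compound 1 to compound 3 (within the scatter) and it is expected to remain a small one. Compound 3 is expected at 15% with an estimated range from 3% to 35% on this read-out.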

Compound 3, percent growth inhibition at one concentration: 21.8%
Compound 3: middle estimate off by 6.8 percentage points, on the low side; the range from low to high includes it.
By their numbers in this assay, from the lowest: compounds 1, 2 and 3 (each within the scatter of the next, the first and the last beyond it).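

In this assay the swap on the sulfur gives a number 11.6 percentage points higher from compound 1 to compound 3 (beyond the scatter), a modest step but the first in this series to lie beyond the scatter, whereas adding a methoxy to the aromatic ring gave only a number 7.9 percentage points higher from compound 1 to compound 2 (within the scatter). The position on the sulfur therefore responds to replacing the whole group more clearly than to adding to its ring, even though 4-methoxyphenyl and phenethyl both hold 8 heavy atoms and one six-membered aromatic ring of carbon only, and differ in that phenethyl has no oxygen and no hydrogen-bond acceptor. Nothing given here accounts for why the number moves with this change.

The compounds shown cannot separate the effect of losing the methoxy from that of placing a saturated chain between the sulfur and the ring, since both differences arrive together in compound 3. They also leave open how a plain phenyl, a benzyl, a longer chain such as 3-phenylpropyl, or a phenethyl carrying a methoxy or an amine on its ring would behave on the sulfur.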